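The source may hold more compounds than are shown below. What is called first, only, known or untested is meant among the compounds shown, and "the series" means these compounds.

Compound 1 `O=C(NC1CCN(Cc2ccc(OC3CCNCC3)c(Br)c2)CC1)c1ccco1`: 770 nM
Compound 2 `CCc1ccc2sc(C(=O)NC3CCN(Cc4ccc(OC5CCNCC5)c(Br)c4)CC3)cc2c1`: 180 nM

For the measured compounds named here, of the two compounds measured in an assay on HEK293 cells for displacement of a labelled ligand from Urotensin-2 receptor (Homo sapiens), read by fluorescence, with a stated time of 90 min (a higher number here means a weaker inhibitor, a lower number a stronger inhibitor), compound 2 has the lower number, and the only measured step, a 4.3-fold lower number from compound 1 to compound 2 (0.63 log units; beyond the scatter), changes the whole group on the carbonyl carbon. Compound 3 `COc1ccc2sc(C(=O)NC3CCN(Cc4ccc(OC5CCNCC5)c(Br)c4)CC3)cc2c1` differs from compound 2 by methoxy in place of ethyl on an aromatic carbon. Going by the values given here, no measured step touches that position, so the one step on record gives no direct guide for this change. Compound 3 is therefore expected to give about 250 nM in this assay, with a range of 100 nM to 700 nM. The expected step of a 1.4-fold higher number from compound 2 to compound 3 (0.14 log units; within the scatter) lies within the scatter.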

Compound 3, half-maximal inhibitory concentration: 100 nM
Compound 3: middle estimate off by 2.5-fold (0.40 log units), on the high side; low and high end bracket the measured number.
By their numbers in this assay, from the lowest: compounds 3 and 2 (each within the scatter of the next); then compound 1.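

In this assay, methoxy in place of ethyl on this aromatic carbon gives a 1.8-fold lower number from compound 2 to compound 3 (0.26 log units; within the scatter), so these two groups, equal in heavy-atom count, cannot be told apart here. The step to the methoxy compound from the furan, a 7.7-fold lower number from compound 1 to compound 3 (0.89 log units; beyond the scatter), shows that the lower number seen with the ethyl-bearing group also holds with methoxy. Nothing available explains either step.

From the compounds shown here alone, whether an amine or a carboxylic acid on this same aromatic carbon would give a similar number remains open. So does the outcome with a longer chain, such as propoxy.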